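A Triazole Substituent Swap on Two Weakly Active Cores

The source may report more compounds than this note shows. Statements on the series, on what has been measured and on what is new or still open speak of the compounds shown alone.

Compound 1 `CCCCCc1ccc(C#Cc2c(-c3ccc(CCCCC)cc3)oc3nc(=O)n(Cc4cn(-c5ccc(Cl)cc5)nn4)cc23)cc1`: > 100000 nM, a limit of the assay
Compound 2 `CCCCCc1ccc(C#Cc2c(-c3ccc(CCCCC)cc3)oc3nc(=O)n(Cc4cn(Cc5ccccc5)nn4)cc23)cc1`: > 100000 nM, a limit of the assay
Compound 3 `O=c1nc2oc(CCCCl)cc2cn1Cc1cn(Cc2ccccc2)nn1`: 75500 nM

All three were tested in a functional assay on SW-620 cells (Homo sapiens) for antiproliferative activity, read by MTT assay, with a stated time of 72 h; a lower number here means a stronger inhibitor, a higher number a weaker inhibitor. Compound 1 gives only a limit there. Compound 2 likewise gives only a limit, so the step that the two limits leave unreadable from compound 2 to compound 1, which is 4-chlorophenyl in place of benzyl on an aromatic nitrogen, cannot be sized; both sit at the limit of > 100000 nM in this assay, at which 2 of the 3 values shown sit. Among the measured compounds shown here, compound 3 is the one compound with a measured number, and it is a weak inhibitor.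

Compound 4 `O=c1nc2oc(CCCCl)cc2cn1Cc1cn(-c2ccc(Cl)cc2)nn1` carries the same change on the core of compound 3: 4-chlorophenyl in place of benzyl on an aromatic nitrogen. The difference between the core of compound 3 and that of compound 2 is not broken down here. Because a step that the two limits leave unreadable from compound 2 to compound 1 is unreadable and gives no direction, the expectation for compound 4 rests on compound 3 alone, with 75500 nM as the anchor. The expected step of a 1.1-fold lower number from compound 3 to compound 4 (0.03 log units; within the scatter) is therefore estimated as small. Compound 4 is estimated at 70000 nM in this assay, between 20000 nM and 100000 nM.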

Compound 4, half-maximal inhibitory concentration: > 100000 nM
Compound 4 gave a limit, no number (the forecaster's own chance of this, stated with the estimate: 40%); at least 1.4-fold (0.15 log units) between middle value and limit.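

Putting 4-chlorophenyl in place of benzyl on an aromatic nitrogen gives an at least 1.3-fold higher number from compound 3 to compound 4 (0.12 log units; that floor lies within the scatter) in this assay. Going by these compounds, the change therefore brings no lower number on this core, but one end of the step is a limit, so its true size stays unknown and no real loss can be claimed. The same change on the core of compound 2 cannot be read, so nothing here shows whether the change carries from one core to the other, and the set as a whole offers little room for reading any step: the limit of > 100000 nM in this assay, at which 3 of the 4 values shown sit.

The compounds shown leave open whether a group on that nitrogen could bring a clearly lower number than the plain benzyl of compound 3, for example a benzyl carrying an amine or a carboxylic acid. They also leave open what a longer chain in place of the chlorine-bearing chain on the core of compound 3 would do.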